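A Methoxy Group Added to an Inactive Series

A few compounds are considered here, and "the series" means these few. Any claim that something is new, unique, unknown or untested is made for them only; others in the source may bear on it.

Of the compounds shown here, three of the shared core have so far been tested in a functional assay on NCI-H460 cells (Homo sapiens) for cytotoxicity, read by MTT assay; a higher number here means a weaker inhibitor, a lower number a stronger inhibitor. Compound 1 `COc1cccc(/C=C/C(=O)c2sc(Nc3cccc(C)c3)nc2C)c1` gives > 25000 nM, which is a limit of the assay and not a measured number. Compound 2 `COc1cccc(/C=C/C(=O)c2sc(Nc3ccc(Cl)cc3)nc2C)c1` gives > 25000 nM, again only a limit. Because both ends sit at a limit, the step that the two limits leave unreadable from compound 1 to compound 2 cannot be read in size or direction. Compound 3 `Cc1nc(Nc2cccc(Cl)c2)sc1C(=O)/C=C/c1ccccc1` stands at the same place: in this assay compound 3 gives > 25000 nM, once more a limit rather than a number. Within the data shown here, every measured value therefore rests at the limit of > 25000 nM in this assay, at which 3 of the 3 values shown sit, so no compound can be called stronger or weaker than another.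

Compound 4 `COc1cccc(/C=C/C(=O)c2sc(Nc3cccc(Cl)c3)nc2C)c1` differs from compound 3 in a single point: methoxy in place of hydrogen on an aromatic carbon. Among the measured compounds shown here, the only step between measured compounds, a step that the two limits leave unreadable from compound 1 to compound 2, does not involve this change and is itself unreadable, so nothing measured bears directly on it. With every neighbour at the limit, the step that the limit leaves unreadable from compound 3 to compound 4 is expected to show no difference beyond the usual scatter. For compound 4 the estimated value in this assay is 35000 nM, expected to fall between 10000 nM and 120000 nM, most likely reported again as a limit.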

Compound 4, half-maximal inhibitory concentration: > 25000 nM
Compound 4: only a limit was reported; the forecaster's own chance of this, stated with the estimate: 80%; the middle value does not contradict the limit.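

In this assay compound 4 gives > 25000 nM, which is a limit and not a number. The steps to compound 4 from compound 1, compound 2 and compound 3 therefore cannot be read, in size or in direction: the limit of > 25000 nM in this assay, at which 4 of the 4 values shown sit. The compounds shown leave open how strong each of them really is and whether any of these changes to the shared core makes a difference.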